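Removing the chloro group from an inactive series

A few compounds are considered here, and "the series" means these few. Any claim that something is new, unique, unknown or untested is made for them only; others in the source may bear on it.

Compound 1 `Cc1ccccc1C(c1ccccc1)N1CCN(c2ncnc3c2cnn3-c2ccccc2)CC1`, compound 2 `N#Cc1cccc(C(c2ccccc2)N2CCN(c3ncnc4c3cnn4-c3ccccc3)CC2)c1` and compound 3 `Clc1ccc(C(c2ccccc2)N2CCN(c3ncnc4c3cnn4-c3ccccc3)CC2)cc1` share the same core and differ only in the aryl group on a saturated chain carbon bound to an amine nitrogen in a ring and an aromatic carbon. In a functional assay on cells (Rhabdomyosarcoma cell, Homo sapiens) for cytotoxicity (on this read-out lower numbers stand for stronger inhibition and higher numbers for weaker inhibition), compound 1 reaches only the limit of the assay, > 25000 nM. Compound 2 likewise gives only a limit, > 25000 nM. Compound 3 also stops at a limit, > 25000 nM. Because all three sit at the limit of > 25000 nM in this assay, at which 3 of the 3 values shown sit, none of the steps among them can be read: a step that the two limits leave unreadable from compound 1 to compound 2, a step that the two limits leave unreadable from compound 1 to compound 3 and a step that the two limits leave unreadable from compound 2 to compound 3. Compound 3 therefore stands at the same limit as the other two, with no number of its own.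

Compound 4 `c1ccc(C(c2ccccc2)N2CCN(c3ncnc4c3cnn4-c3ccccc3)CC2)cc1` is the unmeasured partner of compound 3; the change is hydrogen in place of chloro on an aromatic carbon. Going by the values given here, no measured step covers the change from 4-chlorophenyl to phenyl, and the measured steps bear on it only in that every exchange of the aryl group so far, 2-methylphenyl, 3-cyanophenyl or 4-chlorophenyl, left the readout at its limit. From that, no step beyond the scatter is expected in this assay, and the most likely outcome is once more a limit. The step from compound 3 to compound 4 is estimated as a step that the limit leaves unreadable from compound 3 to compound 4. Compound 4 is expected to give about 40000 nM, within a range of 10000 nM to 200000 nM.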

Compound 4, half-maximal inhibitory concentration: > 25000 nM
Compound 4 was reported as a limit (the forecaster's own chance of this, stated with the estimate: 85%); the middle value is on the limit's open side.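

In this assay compound 4 gives only a limit (> 25000 nM). Its steps to compound 1, compound 2 and compound 3 cannot be read, because all four compounds stop at the same limit: the limit of > 25000 nM in this assay, at which 4 of the 4 values shown sit.

The compounds shown leave open what the actual values of these four compounds are, and whether any change of aryl group alters cytotoxicity at all.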